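The source may report more compounds than this note shows. Statements on the series, on what has been measured and on what is new or still open speak of the compounds shown alone.

Measured so far in a functional assay on A549 cells (Homo sapiens) for inhibition, read by MTT assay, with a stated time of 48 h; a lower number here means a stronger inhibitor, a higher number a weaker inhibitor:
compound 1 `C[Se]c1ccc(N(C)c2nc(C3CC3)nc3ccccc23)cc1`: 13 nM
compound 2 `COc1ccc(N(C)c2nc(C)nc3ccccc23)cc1OCCCCCC[Se]C#N`: 5520 nM
compound 3 `COc1ccc(N(C)c2nc(C)nc3ccccc23)cc1C(=O)OCCC[Se]C#N`: 250 nM

Compound 2 stands at the highest number of the three. Its nearest neighbour is compound 3, reached by a 22-fold lower number from compound 2 to compound 3 (1.34 log units; beyond the scatter); compound 1 lies furthest away, with a far lower number still.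

Compound 4 `COc1ccc(N(C)c2nc(C)nc3ccccc23)cc1OCC[Se]C#N` is next to be measured in this assay. Against compound 2 the change is a group of 3 heavy atoms (1 carbon, 1 nitrogen, 1 selenium; no ring) in place of a group of 7 heavy atoms (5 carbon, 1 nitrogen, 1 selenium; no ring), on a saturated chain carbon, two bonds along the chain from an oxygen on an aromatic ring. The chain that leaves is replaced by a much shorter one ending in the same group, and the oxygen on the aromatic ring is kept.

Within the data shown here, only one measured step bears on this. The step from compound 2 to compound 3 also swaps the long chain on the same aromatic carbon for a shorter arrangement, and it gave a 22-fold lower number from compound 2 to compound 3 (1.34 log units; beyond the scatter). Among the measured compounds shown here, no measured pair isolates chain length alone, so the expectation rests on compound 2 and compound 3 alone and is uncertain in size.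

For compound 4 a lower number than compound 2 is expected, but a smaller move than the step to compound 3. The estimate for compound 4 is 900 nM, with a range from 200 nM to 4000 nM. This estimate corresponds to an expected step of a 6.1-fold lower number from compound 2 to compound 4 (0.79 log units; beyond the scatter).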

Compound 4, half-maximal inhibitory concentration: 13 nM
Beside the measured number, compound 4's estimate is 69-fold (1.84 log units) above it; measured number outside the range, below it.
By their numbers in this assay, from the lowest: compounds 1 and 4 (each within the scatter of the next); then compound 3; then compound 2.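

In this assay, the group of 3 heavy atoms in place of the group of 7 heavy atoms, on a saturated chain carbon, two bonds along the chain from an oxygen on an aromatic ring, gives a 420-fold lower number from compound 2 to compound 4 (2.63 log units; beyond the scatter) with the oxygen kept. Among these compounds, this pair isolates chain length at this position, which the earlier compounds could not do, and shows that shortening the chain alone moves the number strongly. The change on the aromatic carbon gives a 19-fold lower number from compound 3 to compound 4 (1.28 log units; beyond the scatter) and so shows that the carbonyl-containing chain of compound 3 recovers only part of the gain seen with compound 4; no measured evidence here accounts for either step.

With only the long and short chains on this oxygen shown, it remains open whether the number falls steadily with chain length or changes abruptly at some intermediate length, such as a butyl linker. Also open, as far as these compounds go, is whether the short chain needs its selenium and nitrile end, which a sulfur in place of the selenium or a terminal amine in place of the nitrile would test.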